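This account rests on a few compounds, and the source may have more. Where it says the series, first, only, none or still open, it means among the compounds named here.

Measured so far:
- compound 1, `CCCCCCCN(CCCCCSc1cc(-c2ccccc2)cnn1)C(=O)Nc1ccc(F)cc1F`, gives 75% in an assay on microsomes from liver for inhibition of sterol O-acyltransferase 1 (Rattus norvegicus), tested at 50 ug/mL; a higher number here means more inhibition at the concentration tested (going by the name of the read-out), a lower number less inhibition
- compound 2, `CCCCCCCN(CCCCCSc1ccc(-c2ccccc2)nn1)C(=O)Nc1ccc(F)cc1F`, gives 44% in this assay
- compound 3, `CCCCCCCN(CCCCCS(=O)(=O)c1cc(-c2ccccc2)cnn1)C(=O)Nc1ccc(F)cc1F`, gives 67% in this assay

Compound 1 and compound 2 share everything except the arrangement of the ring pair attached to the sulfur. That change is a group of 12 heavy atoms (10 carbon, 2 nitrogen; one six-membered aromatic ring of carbon only, one six-membered aromatic ring with 2 hetero atoms) in place of a group of 12 heavy atoms (10 carbon, 2 nitrogen; one six-membered aromatic ring of carbon only, one six-membered aromatic ring with 2 hetero atoms), on a sulfur. The step it made was a number 31 percentage points lower from compound 1 to compound 2 (beyond the scatter), a clear drop in inhibition.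

Compound 3 carries the same ring pair as compound 1, but on a sulfonyl sulfur rather than a plain sulfur; the difference between the two cores is not broken down here. In this assay compound 3 and compound 1 sit within the usual scatter of each other, so no order between them can be read from these numbers.

Compound 4, `CCCCCCCN(CCCCCS(=O)(=O)c1ccc(-c2ccccc2)nn1)C(=O)Nc1ccc(F)cc1F`, has not yet been measured. It differs from compound 3 by a group of 12 heavy atoms (10 carbon, 2 nitrogen; one six-membered aromatic ring of carbon only, one six-membered aromatic ring with 2 hetero atoms) in place of a group of 12 heavy atoms (10 carbon, 2 nitrogen; one six-membered aromatic ring of carbon only, one six-membered aromatic ring with 2 hetero atoms), on a sulfonyl sulfur. Within the data shown here, this is the same kind of change as the one from compound 1 to compound 2, now made on a sulfonyl sulfur instead of a sulfur. On that single precedent, a step of similar size is expected, namely a number 29 percentage points lower from compound 3 to compound 4 (beyond the scatter), because the earlier step was a number 31 percentage points lower from compound 1 to compound 2 (beyond the scatter). Among the measured compounds shown here, with only one prior example, the expected range is kept wide. The estimate for compound 4 in this assay is 38%, with a range from 20% to 56%.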

Compound 4, a percentage reported as inhibition, at one concentration (the size of the read-out at that concentration, not a potency): 43%
Estimate against measurement, compound 4: 5 percentage points below; low and high end bracket the measured number.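

In this assay, putting the 6-phenylpyridazin-3-yl group on the sulfonyl sulfur gave a number 24 percentage points lower from compound 3 to compound 4 (beyond the scatter), so the rearrangement of the ring pair lowers the number here as well. Among these compounds, this does not show that the change would behave the same way on every core: it rests on only two pairs of compounds, whose cores differ only at the sulfur, and the numbers give the inhibition at a single concentration, not a potency. They also give no reason for the drop, but within these two pairs the change carries over from a sulfur to a sulfonyl sulfur, with steps that cannot be told apart in size: the same change on two cores in this assay, a number 31 percentage points lower (beyond the scatter) from compound 1 to compound 2 and a number 24 percentage points lower (beyond the scatter) from compound 3 to compound 4, 7 percentage points apart, within the scatter of two such steps.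

The compounds shown leave open whether the same step would appear with an oxygen in place of the sulfur, or with a longer chain on the urea nitrogen. They also leave open what an amine or a carboxylic acid on the phenyl ring would do, and whether the ring-pair change would then still lower the inhibition by a similar amount.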